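A few compounds are considered here, and "the series" means these few. Any claim that something is new, unique, unknown or untested is made for them only; others in the source may bear on it.

In a functional assay on HCT-116 cells (Homo sapiens) for inhibition (a lower number here means a stronger inhibitor, a higher number a weaker inhibitor), three compounds share one core and differ only in the amino group on a saturated chain carbon. Compound 1 `CCNC(=O)c1noc(-c2cc(C(C)C)c(O)cc2O)c1-c1cc(CNC)no1` gives 164 nM, compound 2 `CCNC(=O)c1noc(-c2cc(C(C)C)c(O)cc2O)c1-c1cc(CN(CC)CC)no1` gives 38 nM and compound 3 `CCCN(CCC)Cc1cc(-c2c(C(=O)NCC)noc2-c2cc(C(C)C)c(O)cc2O)on1` gives 183 nM. Compound 3 thus belongs to the high end of this small range, not separated from its nearest neighbour. The steps read a 1.1-fold higher number from compound 1 to compound 3 (0.05 log units; within the scatter) and a 4.8-fold higher number from compound 2 to compound 3 (0.68 log units; beyond the scatter).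

Compound 4 `CCNC(=O)c1noc(-c2cc(C(C)C)c(O)cc2O)c1-c1cc(C(=O)NC)no1` brings a larger change, methylcarbamoyl in place of (dipropylamino)methyl on an aromatic carbon. The measured steps only exchange one amino group for another, so they bear on this change loosely. They run from within the scatter to modest, as in a 4.3-fold lower number from compound 1 to compound 2 (0.64 log units; beyond the scatter), and their direction does not follow chain size. Among the compounds with values here, no measured compound carries methylcarbamoyl, so the data give no direction, and no step beyond the scatter is expected, though with wide uncertainty. The expected step is a 1.1-fold higher number from compound 3 to compound 4 (0.04 log units; within the scatter). For compound 4 the estimated value is 200 nM, with an expected range from 50 nM to 800 nM.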

Compound 4, half-maximal inhibitory concentration: 124 nM
Compound 4: middle estimate off by 1.6-fold (0.21 log units), on the high side; the range from low to high includes it.
By their numbers in this assay, from the lowest: compound 2; then compounds 4, 1 and 3 (each within the scatter of the next).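

In this assay, a group with no amino nitrogen on a saturated chain carbon still gives a number in the same range as two of the amines: a 1.5-fold lower number from compound 3 to compound 4 (0.17 log units; within the scatter) and a 1.3-fold lower number from compound 1 to compound 4 (0.12 log units; within the scatter) both stay within the scatter. So among these compounds, an amino group at this position is not needed for that level of inhibition. The (diethylamino)methyl group still stands apart, as a 3.3-fold higher number from compound 2 to compound 4 (0.51 log units; beyond the scatter) lies beyond the scatter and compound 2 keeps the lowest number of the four. No measurement here explains these differences.

As far as these compounds go, it remains open whether a carboxylic acid or a longer amide such as ethylcarbamoyl would behave like methylcarbamoyl at this position. From the compounds shown here alone, it is also open whether dimethylamino or a ring amine such as morpholine on the chain carbon would match compound 2.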